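The compounds below may be only part of what the source reports. "The series", "measured", "known", "first", "only" and "open" are said of these compounds alone.

Values in an ADME assay on microsomes from liver (Homo sapiens) for metabolic stability, read by LC-MS, using NADPH, with a stated time of 30 min, tested at 0.1 uM, in the presence of a further agent that is not named here; a higher number here means that more of the compound is left, a lower number that less of the compound is left:

Compound 1 `Nc1ncc(-c2ccc(C(=O)N3CC(O)C3)cc2)nc1-c1ccc(C(F)(F)F)cc1` gives > 90% as a limit
Compound 2 `Nc1ncc(-c2ccc(C(=O)N3CCC(O)C3)cc2)nc1-c1ccc(C(F)(F)F)cc1` gives > 90% as a limit
Compound 3 `Nc1ncc(-c2ccc(C(=O)N3CC[C@H](O)C3)cc2)nc1-c1ccc(C(F)(F)F)cc1` gives > 90% as a limit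

Compound 3 stands at a shared ceiling, (the limit of > 90% in this assay, at which 3 of the 3 values shown sit), so its true place in the series is not known. The change to compound 4 `Nc1ncc(-c2ccc(C(=O)O)cc2)nc1-c1ccc(C(F)(F)F)cc1` is hydroxy in place of 3-hydroxypyrrolidin-1-yl on a carbonyl carbon, in words hydroxy in place of 3-hydroxypyrrolidin-1-yl on a carbonyl carbon. The measured steps nearest to it are a step that the two limits leave unreadable from compound 1 to compound 3, at the same place, and a step that the two limits leave unreadable from compound 2 to compound 3. Going by the values given here, neither gives a size, and no measured compound carries carboxy. The expectation therefore rests only on compound 3 with > 90%, which is a limit. The expected step of a number no higher from compound 3 to compound 4 (the limit leaves the size open) is none beyond the usual scatter, with no direction favoured. The estimate for compound 4 is 90%, with an expected range from 72% to 100%.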

Compound 4, percent of the compound remaining in the Homo sapiens assay: > 90%
Compound 4: only a limit was reported; the forecaster's own chance of this, stated with the estimate: 55%; the middle value lies on the limit itself.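

In the Homo sapiens assay compound 4 gives > 90%, which is a limit.

In the Homo sapiens assay no step to compound 4 from compound 1, compound 2 or compound 3 can be read, since all four compounds sit at the same limit: the limit of > 90% in the Homo sapiens assay, at which 4 of the 4 values shown sit.

The compounds shown leave open how much of each one actually remains, and so whether they differ at all.

In a physicochemical assay for solubility, read by HPLC, using the shake flask method, with a stated time of 2 h, at pH 2 (a higher number here means a more soluble compound, a lower number a less soluble compound), compound 3 gives 93000 nM.

In the physicochemical assay compound 4 gives < 5000 nM, which is a limit.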